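Nitroimidazooxazine series: cytotoxicity on MRC5 cells

The source may hold more compounds than are shown below. What is called first, only, known or untested is meant among the compounds shown, and "the series" means these compounds.

For the measured compounds named here, compound 1 `O=[N+]([O-])c1cn2c(n1)OC(COc1cccc(-c3ccc(F)cc3F)n1)CC2` is the first of three compounds measured in an ADME assay on MRC5 cells (Homo sapiens) for cytotoxicity, read by resazurin assay, with a stated time of 72 h; on this read-out lower numbers stand for stronger inhibition and higher numbers for weaker inhibition. In this assay compound 1 gives only a limit, > 64000 nM. Compound 2 `O=[N+]([O-])c1cn2c(n1)OC(COc1ccc(-c3ccc(F)nc3)cc1)CC2` carries a different core; the difference between the two cores is not broken down here. In this assay compound 2 also gives only a limit, > 64000 nM. Compound 3 `CC1(COc2cccc(-c3ccc(F)cc3F)n2)CCn2cc([N+](=O)[O-])nc2O1` differs from compound 1 by one change, (methyl in place of hydrogen on a saturated ring carbon), and in this assay compound 3 gives only a limit, > 64000 nM. The step that the two limits leave unreadable from compound 1 to compound 3 therefore cannot be read, since both ends sit at the limit of > 64000 nM in this assay, at which 3 of the 3 values shown sit.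

Compound 4 `CC1(COc2ccc(-c3ccc(F)nc3)cc2)CCn2cc([N+](=O)[O-])nc2O1` has not yet been measured. It differs from compound 2 by the same change, (methyl in place of hydrogen on a saturated ring carbon), in the same place as between compound 1 and compound 3. Because all three measured values sit at the limit of > 64000 nM in this assay, at which 3 of the 3 values shown sit, no size can be assigned to the earlier step, and the expected step that the limit leaves unreadable from compound 2 to compound 4 is likewise taken as unreadable. Compound 4 is expected to give 100000 nM in this assay, with a range of 50000 nM to 300000 nM, most probably reported again only as a limit.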

Compound 4, half-maximal inhibitory concentration: > 64000 nM
Compound 4 gave a limit, no number; the forecaster's own chance of this, stated with the estimate: 85%; the middle value does not contradict the limit.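

No step can be read from compound 2 to compound 4, because both give a limit and not a number: the limit of > 64000 nM in this assay, at which 4 of the 4 values shown sit.

The compounds shown leave open whether methyl in place of hydrogen on a saturated ring carbon changes the value in this assay, since none of them gives a number there.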